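Morpholine replaces the bicyclic diamine on the shared core

The source may report more compounds than this note shows. Statements on the series, on what has been measured and on what is new or still open speak of the compounds shown alone.

Measured compounds in a physicochemical assay for lipophilicity; a lower number here means a more polar compound, a higher number a more lipophilic compound:
compound 1 `CC(C)Sc1nnc(-c2c(CNC3CC3)c3ccccc3n2C)n1-c1ccccc1` gives 4.81;
compound 2 `CC(C)Sc1nnc(-c2c(CNc3nc4ccccc4[nH]3)c3ccccc3n2C)n1-c1ccccc1` gives 5.94;
compound 3 `CC(C)Sc1nnc(-c2c(CN3CCC(N4CCCC4)CC3)c3ccccc3n2C)n1-c1ccccc1` gives 5.16.

Compound 3 stands second highest of the three, below compound 2 and above compound 1. Its step from compound 1 was a number 0.35 log units higher from compound 1 to compound 3 (beyond the scatter), and from compound 2 it was a number 0.78 log units lower from compound 2 to compound 3 (beyond the scatter). Compound 4 `CC1CN(Cc2c(-c3nnc(SC(C)C)n3-c3ccccc3)n(C)c3ccccc23)CC(C)O1` carries the change (2,6-dimethylmorpholin-4-yl in place of 4-(pyrrolidin-1-yl)piperidin-1-yl on a saturated chain carbon bound to an aromatic carbon). Within the data shown here, no measured step swaps one saturated amine ring for another; the nearest guide is the modest rise from compound 1 to compound 3, so a change on this side of the core has so far moved this assay only modestly. The step from compound 3 to compound 4 is therefore expected to be a number 0.16 log units lower from compound 3 to compound 4 (within the scatter), within the scatter. Compound 4 is estimated at 5, between 4.5 and 5.5.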

Compound 4, partition coefficient: 5.13
The estimate for compound 4 lay 0.13 log units below the measured number; low and high end bracket the measured number.
By their numbers in this assay, from the lowest: compound 1; then compounds 4 and 3 (each within the scatter of the next); then compound 2.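

In this assay, 2,6-dimethylmorpholin-4-yl in place of 4-(pyrrolidin-1-yl)piperidin-1-yl gives a number 0.03 log units lower from compound 3 to compound 4 (within the scatter) and so shows that two quite different saturated amine rings, one with fewer heavy atoms and with a ring oxygen, can read alike on this saturated chain carbon. The other steps, a number 0.81 log units lower from compound 2 to compound 4 (beyond the scatter) and a number 0.32 log units higher from compound 1 to compound 4 (beyond the scatter), place compound 4 with compound 3, under compound 2 and over compound 1. No supporting data bear on why these two rings read alike. Still open, as far as these compounds go, is whether plain morpholine, without the two methyl groups, would read the same, and whether a carboxylic acid at this place would leave this range.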